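The source may report more compounds than this note shows. Statements on the series, on what has been measured and on what is new or still open speak of the compounds shown alone.

In an ADME assay on CHO-K1 cells (Cricetulus griseus) for cytotoxicity, read by MTT assay, with a stated time of 24 h (a higher number here means a weaker inhibitor, a lower number a stronger inhibitor), compound 1 (`CCCCCCCC(=O)Nc1nnc(S[C@@H]2O[C@H](CO)[C@H](O)[C@H](O)[C@H]2O)s1`) gives 60100 nM as its result. Compound 2 (`CCCCCCCC/C=C\CCCCCCCC(=O)Nc1nnc(S[C@@H]2O[C@H](CO)[C@H](O)[C@H](O)[C@H]2O)s1`) is recorded as "not active" (no number reported) and compound 3 (`CCCCCC(=O)Nc1nnc(S[C@@H]2O[C@H](CO)[C@H](O)[C@H](O)[C@H]2O)s1`) as "not active" (no number reported) with no single number to place it. Compound 4 (`CCCCCCCCCCCCCCCC(=O)Nc1nnc(S[C@@H]2O[C@H](CO)[C@H](O)[C@H](O)[C@H]2O)s1`) departs from compound 3 by decyl in place of hydrogen on a saturated chain carbon, five bonds along the chain from a carbonyl carbon with the rest of the structure unchanged. No measured step sizes this change in this assay and the three results show no clear order along the chains. Within the data shown here, a modest outcome is expected, a weak but readable value, with compound 1 at 60100 nM as the only numerical guide and no clear gain in strength over it. Compound 4 is estimated at 60000 nM in an expected range from 20000 nM to 180000 nM if a number is reported at all.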

Compound 4, half-maximal inhibitory concentration: "not active" (no number reported)
The entry for compound 4 holds no number; the estimate stays without a comparison.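

Compound 3 and compound 4 both stand without a number in this assay, and no new step can be read between them. The compounds shown leave open how chain length relates to the result. No supporting evidence bears on this result.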